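Working notes: from tert-butyl to methoxy on compound 3

The source may report more compounds than this note shows. Statements on the series, on what has been measured and on what is new or still open speak of the compounds shown alone.

- compound 1 `CN1CCN(c2ccc(Nc3ncc(Cl)c(NCc4ccc(C(F)(F)F)cc4)n3)nc2)CC1`: 26200 nM
- compound 2 `COc1ccccc1CNc1nc(Nc2ccc(N3CCN(C)CC3)cn2)ncc1Cl`: 25500 nM
- compound 3 `CN1CCN(c2ccc(Nc3ncc(Cl)c(Nc4ccc(C(C)(C)C)cc4)n3)nc2)CC1`: 6070 nM

In an ADME assay on L02 cells (Homo sapiens) for inhibition, read by CCK-8 assay, with a stated time of 48 h (on this read-out higher numbers stand for weaker inhibition of growth and lower numbers for stronger inhibition of growth), compound 3 gives 6070 nM, the lowest of the three numbers, and its gaps to the other two lie beyond the scatter. The next structure is compound 4 `COc1ccc(Nc2nc(Nc3ccc(N4CCN(C)CC4)cn3)ncc2Cl)cc1`, with this change: methoxy in place of tert-butyl on an aromatic carbon. In words, methoxy replaces tert-butyl on an aromatic carbon.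

Within the data shown here, no measured step makes this exact change. Two steps bring in 4-(tert-butyl)phenyl in place of a benzyl group: a 4.3-fold lower number from compound 1 to compound 3 (0.64 log units; beyond the scatter) and a 4.2-fold lower number from compound 2 to compound 3 (0.62 log units; beyond the scatter). Both alter more than the group at issue, and they cannot show whether the lower number goes with tert-butyl. The remaining step, a 1.0-fold lower number from compound 1 to compound 2 (0.01 log units; within the scatter), puts 2-methoxyphenyl in place of 4-(trifluoromethyl)phenyl but involves no tert-butyl.

On this indirect evidence, part of the gap is expected to return, and the expected step is a 2.1-fold higher number from compound 3 to compound 4 (0.33 log units; beyond the scatter). Compound 4 is estimated at 13000 nM, with an expected range of 5000 nM to 32000 nM.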

Compound 4, concentration for 50% growth inhibition: 3150 nM
Compound 4: the middle estimate sits 4.1-fold (0.62 log units) above what was measured; measured number outside the range, below it.
By their numbers in this assay, from the lowest: compounds 4 and 3 (each within the scatter of the next); then compounds 2 and 1 (each within the scatter of the next).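

At this aromatic carbon, tert-butyl and methoxy are not told apart in this assay: the step is a 1.9-fold lower number from compound 3 to compound 4 (0.28 log units; within the scatter), even though the group shrinks and gains a hydrogen-bond acceptor. The low numbers therefore do not depend on tert-butyl, since 4-methoxyphenyl also stands well clear of both benzyl groups, with an 8.1-fold lower number from compound 2 to compound 4 (0.91 log units; beyond the scatter) and an 8.3-fold lower number from compound 1 to compound 4 (0.92 log units; beyond the scatter). No measurement at hand explains any of these steps.

Still open, as far as these compounds go, is whether an amine or a carboxylic acid on this aromatic carbon would stay level with methoxy and tert-butyl in this assay or move the number beyond the scatter. Also open, from the compounds shown here alone, is how a longer chain in this place would read.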